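The compounds below may be only part of what the source reports. "The series", "measured", "known", "first", "only" and "open" are said of these compounds alone.

Measured compounds in a functional assay on HCT-116 cells (Homo sapiens) for cytotoxicity, read by MTT assay, with a stated time of 72 h; on this read-out higher numbers stand for weaker inhibition and lower numbers for stronger inhibition:
Compound 1 `COc1ncc(-c2ccc3nc(NC(=O)N(C)C)nn3c2)cc1NS(=O)(=O)c1ccc(F)cc1`, for which compound 1 gives 760 nM.
Compound 2 `COc1ncc(-c2ccc3nc(NC(=O)NC4CC4)nn3c2)cc1NS(=O)(=O)c1ccc(F)cc1`, for which compound 2 gives 90 nM.

For the measured compounds named here, compound 2 holds the lowest of the two numbers in this assay; its nearest neighbour is compound 1, and the only measured step runs between them: an 8.4-fold lower number from compound 1 to compound 2 (0.93 log units; beyond the scatter). Compound 3 `CNC(=O)Nc1nc2ccc(-c3cnc(OC)c(NS(=O)(=O)c4ccc(F)cc4)c3)cn2n1` has not yet been measured. Compared with compound 2, the change is methyl in place of cyclopropyl on an amide-type nitrogen.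

Going by the values given here, the one measured step bears on this change only in part: it swapped the whole dimethylamino for cyclopropylamino on the carbonyl carbon, and it showed that the cyclopropyl side gave the lower number. Compound 3 keeps the amide hydrogen of compound 2 and only trades cyclopropyl for methyl, so the step is expected to run back toward compound 1 but to fall short of it. In this assay compound 3 is therefore expected at about 250 nM, with a range of 100 nM to 700 nM, an expected step of a 2.8-fold higher number from compound 2 to compound 3 (0.44 log units; beyond the scatter).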

Compound 3, half-maximal inhibitory concentration: 180 nM
For compound 3 the middle estimate is 1.4-fold (0.14 log units) above the measured one; measured number inside the range.
By their numbers in this assay, from the lowest: compounds 2 and 3 (each within the scatter of the next); then compound 1.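

In this assay, putting methyl in place of cyclopropyl on the amide-type nitrogen gives a 2.0-fold higher number from compound 2 to compound 3 (0.30 log units; within the scatter), so the three-membered ring is not needed at this position and the two groups cannot be told apart here. The clearer difference lies in the other new comparison, hydrogen in place of methyl on the same nitrogen, which gives a 4.2-fold lower number from compound 1 to compound 3 (0.63 log units; beyond the scatter); among these three compounds, the two that keep the amide hydrogen stand together, apart from the dimethylamino compound 1, and the earlier step from compound 1 to compound 2 can now be read largely in this light. Nothing available offers an explanation for this difference.

What the compounds shown leave open is how the position responds to groups larger than cyclopropyl, such as a cyclopentyl ring, a longer chain or a chain ending in an amine. They also leave open whether a plain amino group on the carbonyl carbon would stay with compound 2 and compound 3, and whether the same picture would hold in other cell lines.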